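Hydrazone series: thiophene to furan swap on second core

The source may hold more compounds than are shown below. What is called first, only, known or untested is meant among the compounds shown, and "the series" means these compounds.

Measured in a toxicity assay on HEK-293T cells (Homo sapiens) for cytotoxicity, read by MTT assay, with a stated time of 72 h; a higher number here means a weaker inhibitor, a lower number a stronger inhibitor:
compound 1 `O=C(N/N=C/C1=Cc2ccccc2OC1)c1cccs1`: 22100 nM
compound 2 `O=C(N/N=C/C1=Cc2ccccc2OC1)c1ccco1`: 47300 nM
compound 3 `O=C(N/N=C/C1=Cc2ccccc2OC1c1ccccc1)c1cccs1`: "not determined" (no result reported)

Compound 1 and compound 2 share one core and differ in a single place, (furan-2-yl in place of thiophen-2-yl on a carbonyl carbon). The step is a 2.1-fold higher number from compound 1 to compound 2 (0.33 log units; beyond the scatter), a modest weakening that is nevertheless beyond the usual scatter.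

Compound 3 stands on a second core. Against compound 1 the difference is phenyl in place of hydrogen on a saturated ring carbon. Among the measured compounds shown here, compound 3 has no number in this assay, so the second core has no anchor of its own, and no step can be drawn from it.

Compound 4 `O=C(N/N=C/C1=Cc2ccccc2OC1c1ccccc1)c1ccco1` is the unmeasured partner of compound 3; the change between them is furan-2-yl in place of thiophen-2-yl on a carbonyl carbon. Its place line matches that of the pair compound 1 to compound 2 word for word, so this is the same change, occurring twice among the compounds shown. On the first core this change gave a 2.1-fold higher number from compound 1 to compound 2 (0.33 log units; beyond the scatter). If it behaves on the second core as it did on the first, the step from compound 3 to compound 4 in this assay is expected to be of the same modest size, weakening rather than strengthening. For the measured compounds named here, because compound 3 has no value, the only footing for a number is compound 2 at 47300 nM, with the effect of the phenyl entering the core left open; the range is therefore set wide. Compound 4 is expected to give about 50000 nM, between 12000 nM and 150000 nM.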

Compound 4, half-maximal inhibitory concentration: 11900 nM
Compound 4: the middle estimate sits 4.2-fold (0.62 log units) above what was measured, and the stated range ends above it.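

In this assay the swap of thiophen-2-yl for furan-2-yl can be read on the core of compound 1 only, as a 2.1-fold higher number from compound 1 to compound 2 (0.33 log units; beyond the scatter) shows, and the matching step on the second core cannot be read, as compound 3 has no result. What the new value does give is a step of another kind: with furan-2-yl held fixed, phenyl in place of hydrogen on a saturated ring carbon gives a 4.0-fold lower number from compound 2 to compound 4 (0.60 log units; beyond the scatter) and so moves the number down, a shift beyond the scatter. This shows that the phenyl matters in this series with the furan-2-yl carbonyl in place, but it neither confirms nor refutes that the swap carries over from one core to the other with the same size or direction, and no measurement at hand accounts for the effect of the phenyl.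

Still open, on these data alone, is whether thiophen-2-yl on the second core would sit above or below compound 4, which a number for compound 3 would settle. Also open, as far as these compounds go, is whether the lower number needs an aromatic ring on that saturated ring carbon at all, or whether a methyl group, a cyclohexyl group or an amine there would move the number in the same way.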